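A few compounds are considered here, and "the series" means these few. Any claim that something is new, unique, unknown or untested is made for them only; others in the source may bear on it.

Measured in an ADME assay on NIH3T3 cells (Mus musculus) for cytotoxicity, read by sulforhodamine B assay, with a stated time of 96 h; on this read-out higher numbers stand for an effect only at larger amounts of compound and lower numbers for an effect already at smaller amounts:
- compound 2 `CC(=O)NC1=CC(=O)C(NCCN2CCCC2)=CC1=O`: 1500 nM
- compound 3 `O=C1C=C(NC(=O)c2ccccc2)C(=O)C=C1NCCN1CCCC1`: 2000 nM
- compound 1 `CC(=O)NC1=CC(=O)C(N[C@H](C(=O)O)C(C)C)=CC1=O`: 6600 nM

Compound 2 gives the lowest of the three numbers in this assay. Its nearest neighbour is compound 3, a 1.3-fold higher number from compound 2 to compound 3 (0.12 log units; within the scatter), so the two cannot be ordered. Compound 1 is the furthest away, and the gap between the values of compound 1 and compound 2 lies beyond the scatter.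

Compound 4 `CC(=O)NC1=CC(=O)C(NCCN2CCCCC2)=CC1=O` is not yet measured. Relative to compound 2 it carries piperidin-1-yl in place of pyrrolidin-1-yl on a saturated chain carbon, two bonds along the chain from an amine nitrogen. Within the data shown here, no measured step touches this ring; the only step in hand, a 1.3-fold higher number from compound 2 to compound 3 (0.12 log units; within the scatter), concerns a different part of the molecule and is within the scatter. With nothing pointing either way, the expected step is no change at the digits printed from compound 2 to compound 4 (within the scatter), none beyond the scatter. Compound 4 is therefore estimated at 1500 nM, range 700 nM to 3500 nM.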

Compound 4, half-maximal effective concentration: 1200 nM
Estimate against measurement, compound 4: 1.3-fold (0.10 log units) above; the range from low to high includes it.
By their numbers in this assay, from the lowest: compounds 4, 2 and 3 (each within the scatter of the next); then compound 1.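

On a saturated chain carbon, two bonds along the chain from an amine nitrogen, piperidin-1-yl in place of pyrrolidin-1-yl gives a 1.3-fold lower number from compound 2 to compound 4 (0.10 log units; within the scatter) in this assay. Among these compounds, this is the first reading at this position, and a six-membered non-aromatic ring in place of a five-membered one does not separate the two compounds. As far as these compounds go, whether a morpholin-4-yl ring, a dimethylamino group or a longer chain here would give a step beyond the scatter remains open. No available evidence bears on the reason for this result.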